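Swapping a Tetrazole Thioether for a Phenylpiperazine

This account rests on a few compounds, and the source may have more. Where it says the series, first, only, none or still open, it means among the compounds named here.

Of the compounds shown here, three that share one core have been measured in a functional assay on HT-29 cells (Homo sapiens) for cytotoxicity, read by MTT assay, with a stated time of 24 h, tested at 0.64 ug/mL; on this read-out higher numbers stand for a stronger effect at the one concentration tested and lower numbers for a weaker effect. Compound 1 `Cn1cnnc1SCC(=O)Nc1ccc(-c2nc(-c3ccccc3)c(-c3ccccc3)n2C)cc1` gives 32%. Compound 2 `Cn1nnnc1SCC(=O)Nc1ccc(-c2nc(-c3ccccc3)c(-c3ccccc3)n2C)cc1` gives 38%, the highest of the three numbers, although its gap to compound 1 lies within the scatter: a number 6 percentage points higher from compound 1 to compound 2 (within the scatter). Compound 3 `CCN1CCN(CC(=O)Nc2ccc(-c3nc(-c4ccccc4)c(-c4ccccc4)n3C)cc2)CC1` gives 7.4%. Two measured steps reach it, and both lie beyond the scatter: a number 30.6 percentage points lower from compound 2 to compound 3 (beyond the scatter) and, from the other side, a number 24.6 percentage points lower from compound 1 to compound 3 (beyond the scatter).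

Compound 4 `Cn1c(-c2ccc(NC(=O)CN3CCN(c4ccccc4)CC3)cc2)nc(-c2ccccc2)c1-c1ccccc1` has not yet been measured. It differs from compound 2 in one place: 4-phenylpiperazin-1-yl in place of (1-methyl-1H-tetrazol-5-yl)sulfanyl on a saturated chain carbon bound to a carbonyl carbon. Among the measured compounds shown here, the only measured steps that bear on this exchange are the two in which the group on that same saturated chain carbon was replaced by a piperazinyl group, and both lowered the number well beyond the scatter. Compound 4 carries a 4-phenylpiperazin-1-yl rather than the 4-ethylpiperazin-1-yl of compound 3, so the match is not exact, but the direction is expected to be the same, a drop of roughly a number 26 percentage points lower from compound 2 to compound 4 (beyond the scatter). Compound 4 is therefore expected to give about 12% in this assay , with a likely range from 3% to 30%.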

Compound 4, a percentage reported as activity, at one concentration (the size of the read-out at that concentration, not a potency): 17.3%
The estimate for compound 4 lay 5.3 percentage points below the measured number, within the range that was stated.
By their numbers in this assay, from the lowest: compounds 3 and 4 (each within the scatter of the next); then compounds 1 and 2 (each within the scatter of the next).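

The new result shows that the loss at the saturated chain carbon bound to a carbonyl carbon is not confined to the 4-ethylpiperazin-1-yl group, since in this assay the 4-phenylpiperazin-1-yl group also gives a number 20.7 percentage points lower from compound 2 to compound 4 (beyond the scatter) and a number 14.7 percentage points lower from compound 1 to compound 4 (beyond the scatter). It also tests the far end of the piperazine: phenyl in place of ethyl on an amine nitrogen in a ring gives a number 9.9 percentage points higher from compound 3 to compound 4 (within the scatter), so these two piperazines cannot be told apart in this assay even though the substituents on that nitrogen are quite different. No measurement shown here offers an explanation for why either piperazine sits lower than the two sulfur-linked rings.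

The compounds shown do not separate the contribution of the sulfur from that of the ring attached to it, or show whether a different nitrogen group on the same carbon, such as a morpholine or an open-chain diethylamino group, would behave like the piperazines. With a single concentration in one cell line, they also leave open how these differences would look across a full range of concentrations.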